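The source may report more compounds than this note shows. Statements on the series, on what has been measured and on what is new or still open speak of the compounds shown alone.

Measured so far in a physicochemical assay for lipophilicity, at pH 7.4; a lower number here means a more polar compound, a higher number a more lipophilic compound:
- compound 1 `O=C(O)c1ccc(NC(=O)[C@H](CC2CCCC2)n2cnc(S(=O)(=O)C3CCC3)c2)nc1`: -0.1
- compound 2 `O=C(O)c1ccc(NC(=O)[C@H](CC2CCCCC2)n2cnc(S(=O)(=O)C3CCC3)c2)nc1`: 0.15
- compound 3 `O=C(O)c1ccc(NC(=O)[C@H](CC2CCOCC2)n2cnc(S(=O)(=O)C3CC3)c2)nc1`: -1.85

Compound 3 stands lowest of the three at -1.85. Compound 1 gives -0.1 and compound 2 gives 0.15, both beyond the scatter above it.

The next compound, compound 4 `O=C(O)c1ccc(NC(=O)[C@H](CC2CCOCC2)n2cnc(S(=O)(=O)C3CCC3)c2)nc1`, has not yet been measured. It differs from compound 3 by cyclobutyl in place of cyclopropyl on a sulfonyl sulfur, which means cyclobutyl in place of cyclopropyl on a sulfonyl sulfur. Going by the values given here, no measured pair shows this change on its own. The gaps between compound 3 and the other two compounds mix more than one structural difference and cannot be split.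

Among the compounds with values here, the only measured step that bears on it is a number 0.25 log units higher from compound 1 to compound 2 (within the scatter). There, cyclohexyl replaces cyclopentyl, so a carbon ring also grows, but at another place in the molecule. That makes it a loose guide.

Going by that step alone, a small upward change is expected in this assay, estimated as a number 0.25 log units higher from compound 3 to compound 4 (within the scatter). Compound 4 is expected at -1.6, with an estimated range from -2 to -1.15.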

Compound 4, distribution coefficient: -1.55
Compound 4: middle estimate off by 0.05 log units, on the low side; the range from low to high includes it.
By their numbers in this assay, from the lowest: compounds 3 and 4 (each within the scatter of the next); then compounds 1 and 2 (each within the scatter of the next).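

In this assay, going by these compounds alone, cyclobutyl in place of cyclopropyl on a sulfonyl sulfur gives a number 0.30 log units higher from compound 3 to compound 4 (within the scatter) as the first view of this change on its own, so the larger carbon ring leaves no clear mark at this position in this pair. Within the data shown here, on the saturated chain carbon, oxan-4-yl in place of cyclohexyl gives a number 1.70 log units lower from compound 2 to compound 4 (beyond the scatter) and oxan-4-yl in place of cyclopentyl gives a number 1.45 log units lower from compound 1 to compound 4 (beyond the scatter) in the first comparisons of these rings with the sulfonyl group held constant, and both steps are large. No accompanying measurement accounts for the size of these steps.

Still open, as far as these compounds go, is what a longer chain on the sulfonyl sulfur would give in this assay. Also open, from the compounds shown here alone, is whether a piperidin-4-yl group on the saturated chain carbon would give a number nearer compound 4 or compound 2.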